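Swapping a Cyclohexyl for a Phenoxy Group: Solubility Outlook

The source may hold more compounds than are shown below. What is called first, only, known or untested is meant among the compounds shown, and "the series" means these compounds.

Measured in a physicochemical assay for solubility, with a stated time of 18 h, at pH 7.4; a lower number here means a less soluble compound, a higher number a more soluble compound:
- compound 1 `COc1ccc(F)cc1CNCCCNc1ccnc2cc(C3CCCCC3)ccc12` gives 4200 nM
- compound 2 `COc1cccc(CNCCCNc2ccnc3cc(-c4ccc(C(F)(F)F)cc4)ccc23)c1O` gives 32000 nM
- compound 3 `CCC(CC)c1ccc2c(NCCCNCc3cccc(OC)c3O)ccnc2c1` gives 4200 nM

Compound 1 stands level with compound 3 at the digits shown, and together they are the lowest of the three numbers; compound 2 sits well above, a gap beyond the scatter. Among the compounds with values here, only one single-point step is available: a 7.6-fold lower number from compound 2 to compound 3 (0.88 log units; beyond the scatter). That step replaced an aromatic group by a branched alkyl group on the shared core and lowered the number by a modest amount.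

Compound 4 `COc1ccc(F)cc1CNCCCNc1ccnc2cc(Oc3ccc(C(C)(C)C)cc3)ccc12` differs from compound 1 in one place: 4-(tert-butyl)phenoxy in place of cyclohexyl on an aromatic carbon. The change runs partly against the direction of the step from compound 2 to compound 3, since an alkyl ring leaves and an aromatic, oxygen-linked group enters. Within the data shown here, that step is the only guide, and the entering group also carries a tert-butyl, so the outlook is uncertain. A small rise in this assay is expected, roughly a 1.5-fold higher number from compound 1 to compound 4 (0.19 log units; within the scatter), which may not clear the scatter. Compound 4 is therefore estimated at 6500 nM, with a range from 2000 nM to 20000 nM.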

Compound 4, solubility: 14500 nM
Compound 4: middle estimate off by 2.2-fold (0.35 log units), on the low side; the measured number falls inside the stated range.
By their numbers in this assay, from the lowest: compounds 1 and 3 (each within the scatter of the next); then compound 4; then compound 2.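

In this assay, this position on the shared core accepts 4-(tert-butyl)phenoxy in place of cyclohexyl with a 3.5-fold higher number from compound 1 to compound 4 (0.54 log units; beyond the scatter) as the outcome, so a group with more heavy atoms, an oxygen link and an aromatic ring does not lower the number here. Read alongside a 7.6-fold lower number from compound 2 to compound 3 (0.88 log units; beyond the scatter), this gives two steps, with different groups elsewhere on the molecule, in which the compound carrying an aromatic ring at this position has the higher number, and no compound shown goes against that pattern, though two steps are a thin base. No measurement is available that could explain the rise in this case.

The aromatic ring, the oxygen link and the tert-butyl all enter in a single change, and their separate shares in the step cannot be told apart from these compounds. Plain phenoxy, 4-(tert-butyl)phenyl joined without the oxygen, and a piperidine or a carboxylic acid at this position remain open, as does whether the pattern would hold for any of them.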